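This account rests on a few compounds, and the source may have more. Where it says the series, first, only, none or still open, it means among the compounds named here.

Working notes on the series in an in vitro ADME assay on microsomes from liver (Homo sapiens) for metabolic stability, read by LC-MS, tested at 1 uM; on this read-out higher numbers stand for a longer-lived compound and lower numbers for a shorter-lived compound. Compound 1 `CC(C)n1ccnc1/N=C(\N)Nc1ccc(Cl)c(Cl)c1` returns only a limit of this assay, > 1 h. Compound 2 `N/C(=N\c1nccn1Cc1ccccc1)Nc1ccc(Cl)c(Cl)c1` likewise returns only a limit, > 1 h. The step that the two limits leave unreadable from compound 1 to compound 2 corresponds to the change (benzyl in place of isopropyl on an aromatic nitrogen). Compound 3 `CC(C)C(=O)N/C(=N/c1nccn1C(C)C)Nc1ccc(Cl)c(Cl)c1` also sits at a limit, > 1 h. How the core of compound 3 differs from the core of compound 1 is not broken down here. Within the data shown here, compound 4 `CC(C)C(=O)N/C(=N/c1nccn1Cc1ccccc1)Nc1ccc(Cl)c(Cl)c1` is not yet measured; it differs from compound 3 by benzyl in place of isopropyl on an aromatic nitrogen, the same change as the one between compound 1 and compound 2, at a place described in the same words. The step that the limit leaves unreadable from compound 3 to compound 4 is expected to be close to zero, because of the limit of > 1 h in this assay, at which 3 of the 3 values shown sit. Compound 4 is therefore expected to give 1.5 h, with a range from 0.7 h to 4 h, most likely reported again as a limit.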

Compound 4, half-life: 0.328 h
The estimate for compound 4 lay 4.6-fold (0.66 log units) above the measured number; the measured number lies below the stated range.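

On the core of compound 3, benzyl in place of isopropyl on an aromatic nitrogen gives an at least 3.0-fold lower number from compound 3 to compound 4 (0.48 log units; beyond the scatter) in this assay. The same change from compound 1 to compound 2 cannot be read, as both compounds sit at a limit of the assay, so a drop on that core is neither shown nor excluded. Whether the change carries from one core to the other therefore stays undecided, and no difference between the cores is shown, the comparison ending at the limit: the limit of > 1 h in this assay, at which 3 of the 4 values shown sit.

Going by these compounds, the full size of the step on the core of compound 3 stays open. Also open, on these data alone, is how that core responds to a group other than isopropyl or benzyl on the same aromatic nitrogen, such as a longer chain or a chain ending in an amine or a carboxylic acid.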